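Series notes: 2-chlorophenyl to 4-fluorophenyl swap

A few compounds are considered here, and "the series" means these few. Any claim that something is new, unique, unknown or untested is made for them only; others in the source may bear on it.

Measured so far:
compound 1, `COc1ccc(/C=C2\CN(Cc3cn(Cc4ccc(F)cc4)nn3)C/C(=C\c3ccc(OC)cc3)C2=O)cc1`: 70700 nM
compound 2, `O=C1/C(=C/c2ccccc2F)CN(Cc2cn(Cc3ccccc3Cl)nn2)C/C1=C\c1ccccc1F`: 16500 nM
compound 3, `COc1ccc(/C=C2\CN(Cc3cn(Cc4ccccc4Cl)nn3)C/C(=C\c3ccc(OC)cc3)C2=O)cc1`: > 100000 nM

In a functional assay on MDA-MB-231 cells (Homo sapiens) for cytotoxicity, read by MTT assay, with a stated time of 24 h (on this read-out lower numbers stand for stronger inhibition and higher numbers for weaker inhibition), compound 3 gives only a limit, > 100000 nM, this being (the limit of > 100000 nM in this assay, at which 1 of the 3 values shown sits). Compound 1 carries 4-fluorophenyl in place of 2-chlorophenyl on a saturated chain carbon bound to an aromatic nitrogen, and the step of an at least 1.4-fold lower number from compound 3 to compound 1 (0.15 log units; that floor lies within the scatter) is read against that limit, so it is at best a floor. Compound 2 gives 16500 nM in this assay; the difference between the core of compound 2 and the core of compound 3 is not broken down here, and the two values show compound 2 with the lower number.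

Compound 4, `O=C1/C(=C/c2ccccc2F)CN(Cc2cn(Cc3ccc(F)cc3)nn2)C/C1=C\c1ccccc1F`, differs from compound 2 by 4-fluorophenyl in place of 2-chlorophenyl on a saturated chain carbon bound to an aromatic nitrogen, the same change as from compound 3 to compound 1. Because the earlier step of an at least 1.4-fold lower number from compound 3 to compound 1 (0.15 log units; that floor lies within the scatter) rests on a limit and gives only a floor, a small step is expected here, a 1.4-fold lower number from compound 2 to compound 4 (0.14 log units; within the scatter). Compound 4 is accordingly expected to give about 12000 nM in this assay, with a plausible range from 4000 nM to 40000 nM.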

Compound 4, half-maximal inhibitory concentration: 10000 nM
Beside the measured number, compound 4's estimate is 1.2-fold (0.08 log units) above it, within the range that was stated.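

In this assay, 4-fluorophenyl in place of 2-chlorophenyl gives a 1.7-fold lower number from compound 2 to compound 4 (0.22 log units; within the scatter), so on this core the change cannot be told apart from repeat-measurement noise. Set beside the other core, the comparison stands thus: the same change on two cores in this assay, an at least 1.4-fold lower number (0.15 log units; that floor lies within the scatter) from compound 3 to compound 1 and a 1.7-fold lower number (0.22 log units; within the scatter) from compound 2 to compound 4; the limit leaves it open whether they differ

On these data alone, the value of compound 3, > 100000 nM, is a limit, so the size of the step on that core stays unknown, and the pair neither confirms nor rules out that the change carries over with the same size.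

2-Chlorobenzyl and 4-fluorobenzyl differ in both the halogen and its place on the ring, and the compounds shown do not separate the two, which a 4-chlorobenzyl or 2-fluorobenzyl group would do. Also open, as far as these compounds go, is how an unsubstituted benzyl group, or a longer chain such as phenethyl, would read on the core of compound 2 or the core of compound 3.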